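The source may hold more compounds than are shown below. What is called first, only, known or untested is meant among the compounds shown, and "the series" means these compounds.

Three compounds share one core and were tested in a functional assay on A-375 cells (Homo sapiens) for cytotoxicity, read by MTT assay, with a stated time of 72 h, tested at 10 uM; a lower number here means less inhibition of growth, a higher number more inhibition of growth at the concentration tested. Compound 1 `Cc1ccnc(/C(N)=N/NC(=S)N2CCOCC2)c1` gives 86% in this assay. Compound 2 `Cc1ccnc(/C(N)=N/NC(=S)N2CCSCC2)c1` gives 74.5%. Compound 3 `Cc1ccnc(/C(N)=N/NC(=S)N2CCCCC2)c1` gives 81.2%, the second highest of the three numbers. The measured steps are a number 11.5 percentage points lower from compound 1 to compound 2 (beyond the scatter), a number 4.8 percentage points lower from compound 1 to compound 3 (within the scatter) and a number 6.7 percentage points higher from compound 2 to compound 3 (within the scatter). Compound 4 `Cc1ccnc(/C(N)=N/NC(=S)N2CCCC2)c1` differs from compound 3 by pyrrolidin-1-yl in place of piperidin-1-yl on a thiocarbonyl carbon. The two steps that end at compound 3, a number 4.8 percentage points lower from compound 1 to compound 3 (within the scatter) and a number 6.7 percentage points higher from compound 2 to compound 3 (within the scatter), both lie within the scatter; only a number 11.5 percentage points lower from compound 1 to compound 2 (beyond the scatter) is modest. Among the measured compounds shown here, no measured step changes ring size, so the step of a number 1.2 percentage points lower from compound 3 to compound 4 (within the scatter) is expected to stay within the scatter. Compound 4 is therefore estimated at 80%, between 68% and 90%.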

Compound 4, percent growth inhibition at one concentration: 86%
Estimate against measurement, compound 4: 6 percentage points below; low and high end bracket the measured number.
By their numbers in this assay, from the lowest: compounds 2, 3, 1 and 4 (each within the scatter of the next, the first and the last beyond it).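

Replacing piperidin-1-yl with pyrrolidin-1-yl on the thiocarbonyl carbon gives a number 4.8 percentage points higher from compound 3 to compound 4 (within the scatter) in this assay, so this first change of ring size at the position stays inside the scatter. Among the compounds shown here, the other two steps give no change at the digits printed from compound 1 to compound 4 (within the scatter) and a number 11.5 percentage points higher from compound 2 to compound 4 (beyond the scatter), leaving thiomorpholin-4-yl as the only group set apart, and only from morpholin-4-yl and pyrrolidin-1-yl. Nothing measured here explains these differences. Going by these compounds, it remains open how an azetidin-1-yl or azepan-1-yl ring, or an open-chain diethylamino group, would behave on the thiocarbonyl carbon. Readings at a single concentration also leave compound 1, compound 3 and compound 4 unseparated.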